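The compounds below may be only part of what the source reports. "The series", "measured", "known", "first", "only" and "open" are said of these compounds alone.

Working notes on the series. In a functional assay on CHO cells for agonist activity at Free fatty acid receptor 1 (Homo sapiens), read by FLIPR and calcium flux (a higher number here means that more compound is needed for the effect, a lower number that less compound is needed), compound 1 `COc1cc(C)c(-c2cccc(COc3ccc(S(=O)(=O)CC(=O)O)cc3)c2)c(C)c1` gives 57.5 nM and compound 2 `O=C(O)CS(=O)(=O)c1ccc(OCc2cccc(-c3ccccc3)c2)cc1` gives 288 nM. Among the measured compounds shown here, compound 2 thus stands at the higher of the two numbers so far; its nearest neighbour is compound 1, with a 5.0-fold higher number from compound 1 to compound 2 (0.70 log units; beyond the scatter) marking the step between them, a change that strips the terminal ring down to a bare phenyl.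

Compound 3 `O=C(O)CS(=O)(=O)c1ccc(OCc2cccc(-c3ccccc3F)c2)cc1` is not yet measured in this assay. It differs from compound 2 by fluoro in place of hydrogen on an aromatic carbon; cut one bond further out, the change reads as phenyl to 2-fluorophenyl, with the entering atom sitting ortho to a large group on the six-membered aromatic ring of carbon only.

For the measured compounds named here, only one measured step bears on this position, the step from compound 1 to compound 2, which was modest but beyond the scatter and ran toward a higher number when substituents were removed from this ring. Adding back a single fluoro is a far smaller change, so the step in this assay is expected to be small, estimated as a 1.3-fold lower number from compound 2 to compound 3 (0.12 log units; within the scatter), leaning toward a slightly lower number but not beyond the scatter. For compound 3 the estimated value in this assay is 220 nM, expected within 90 nM to 600 nM.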

Compound 3, half-maximal effective concentration in the Free fatty acid receptor 1 assay: 257 nM
Estimate against measurement, compound 3: 1.2-fold (0.07 log units) below, within the range that was stated.
By their numbers in the Free fatty acid receptor 1 assay, from the lowest: compound 1; then compounds 3 and 2 (each within the scatter of the next).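

In the Free fatty acid receptor 1 assay compound 2 gives 288 nM and compound 3 gives 257 nM, so a single fluoro at this place, on the aromatic carbon ortho to a large group, gives no separable change, with a 1.1-fold lower number from compound 2 to compound 3 (0.05 log units; within the scatter); this one atom does not distinguish the two compounds. Set against the 4-methoxy-2,6-dimethylphenyl of compound 1, the 2-fluorophenyl leaves a gap beyond the scatter, with a 4.5-fold higher number from compound 1 to compound 3 (0.65 log units; beyond the scatter), much as the bare phenyl does with a 5.0-fold higher number from compound 1 to compound 2 (0.70 log units; beyond the scatter), so the single fluoro does not recover what separates compound 1 from compound 2. No measurement at hand gives a reason for either step.

The compounds shown do not separate what the methoxy and the two methyl groups each contribute to the gap to compound 1, nor do they tell whether a chloro or a methyl at this same place would behave as the fluoro does. On these data alone, in a physicochemical assay for lipophilicity, using the shake flask method, in phosphate buffer, measured as octanol-water partition, with a stated time of 24 h, at pH 7.4, tested at 100 uM (a lower number here means a more polar compound, a higher number a more lipophilic compound), compound 2 gives 2.13 and compound 3 is reported as "not determined" (no result reported), so the step between them cannot be read and the effect of this change on that read-out remains open.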